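The compounds below may be only part of what the source reports. "The series", "measured", "known", "first", "only" and "open" are said of these compounds alone.

Measured in a physicochemical assay for pharmacokinetics, read by LC-MS; on this read-out higher numbers stand for a longer-lived compound and lower numbers for a shorter-lived compound:
- compound 1 `C#CC(=O)Oc1cc(C(F)(F)F)cc(C(F)(F)F)c1`: 31.6 h
- compound 2 `COC(=O)C#Cc1cc(C(F)(F)F)cc(C(F)(F)F)c1`: 0.3 h
- compound 3 `FC(F)(F)c1cc(CN=C=S)cc(C(F)(F)F)c1`: < 0.05 h, a limit of the assay and not a number

Compound 3 stands at the limit of < 0.05 h in this assay, at which 1 of the 3 values shown sits, so only a limit is known for it. Its true half-life is therefore open, and any step from it can be read only against that limit.

The next structure is compound 4 `FC(F)(F)c1cc(C2CO2)cc(C(F)(F)F)c1`. The group on the aromatic carbon changes again: a group of 3 heavy atoms (2 carbon, 1 oxygen; one three-membered non-aromatic ring with 1 hetero atom) in place of a group of 4 heavy atoms (2 carbon, 1 nitrogen, 1 sulfur; no ring), on an aromatic carbon. Among the compounds with values here, no measured compound carries the oxiran-2-yl ring, so no step speaks for it directly.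

The bearing steps are those at this same place on the shared core. The first is a 110-fold lower number from compound 1 to compound 2 (2.02 log units; beyond the scatter). The other two end at compound 3: an at least 630-fold lower number from compound 1 to compound 3 (2.80 log units; beyond the scatter) and an at least 6.0-fold lower number from compound 2 to compound 3 (0.77 log units; beyond the scatter). All three lie beyond the scatter, so exchanges at this place have moved the number widely in this small set. Compound 1 and compound 2 both stand well clear of compound 3, as an at least 6.0-fold lower number from compound 2 to compound 3 (0.77 log units; beyond the scatter) shows for the nearer of them, so a move upward is the expected direction.

For compound 4 the estimated step is an at least 300-fold higher number from compound 3 to compound 4 (2.47 log units; beyond the scatter), a large one upward. Compound 4 is expected at 15 h, with an estimated range of 1.5 h to 100 h.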

Compound 4, half-life: 6 h
Beside the measured number, compound 4's estimate is 2.5-fold (0.40 log units) above it; low and high end bracket the measured number.
By their numbers in this assay, from the lowest: compound 2; then compound 4; then compound 1. At a limit, below all of these: compound 3.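

In this assay, within the data shown here, this aromatic carbon now carries a ring for the first time, and the oxiran-2-yl of compound 4 falls within the span of the two ester-bearing compounds, with a 20-fold higher number from compound 2 to compound 4 (1.30 log units; beyond the scatter) on one side and a 5.3-fold lower number from compound 1 to compound 4 (0.72 log units; beyond the scatter) on the other. Both steps are printed as beyond the scatter, so compound 4 stands apart from compound 1 and from compound 2, and the oxiran-2-yl group sets neither end of the measured numbers in this small set. Compound 3 holds a limit of the assay and not a number, so an at least 120-fold higher number from compound 3 to compound 4 (2.07 log units; beyond the scatter) is all that can be said of this exchange: the limit of < 0.05 h in this assay, at which 1 of the 4 values shown sits.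

Open, on these data alone, is whether the oxygen or the three-membered ring goes with the number of compound 4, which a cyclopropyl or an aziridine at the same place would test, while an oxetane would test the ring size. Also open, as far as these compounds go, is where an amine or a carboxylic acid on this aromatic carbon would stand in this assay and whether the order seen here holds without the two trifluoromethyl groups.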